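The source may hold more compounds than are shown below. What is called first, only, known or untested is meant among the compounds shown, and "the series" means these compounds.

Compound 1 `CCC(Nc1ccc(S(=O)(=O)Nc2nccs2)cc1Cl)c1ccccc1` and compound 2 `CC(Nc1ccc(S(=O)(=O)Nc2nccs2)cc1Cl)c1ccccc1` are built on one shared core, and in a physicochemical assay for lipophilicity, read by LC-MS, in phosphate buffer, measured as octanol-water partition, with a stated time of 1 h, at pH 7.4 (on this read-out higher numbers stand for higher lipophilicity and lower numbers for lower lipophilicity), compound 1 gives 3.7 while compound 2 gives 3.2. The change between them, (hydrogen in place of methyl on a saturated chain carbon, two bonds along the chain from an aromatic carbon and a nitrogen on an aromatic ring), brings a number 0.50 log units lower from compound 1 to compound 2 (beyond the scatter). Compound 3 `C[C@H](Nc1cc(F)c(S(=O)(=O)Nc2cscn2)cc1Cl)c1cc(CN2CCC2)ccc1F` stands on another core; how its core differs from that of compound 1 is not broken down here. In this assay compound 3 gives 1.5, the lowest of the three numbers, and its nearest neighbour is compound 2. Compound 4 `O=S(=O)(Nc1cscn1)c1cc(Cl)c(NCc2cc(CN3CCC3)ccc2F)cc1F` has not yet been measured in this assay. Within the data shown here, it differs from compound 3 by hydrogen in place of methyl on a saturated chain carbon bound to an aromatic carbon and a nitrogen on an aromatic ring, which is the same kind of change as the one from compound 1 to compound 2, though the place differs: in compound 3 the saturated chain carbon is bound to an aromatic carbon and a nitrogen on an aromatic ring, whereas in compound 1 it lies two bonds along the chain from them. A step of about the same size is expected here, a number 0.40 log units lower from compound 3 to compound 4 (beyond the scatter), and that expectation rests on a number 0.50 log units lower from compound 1 to compound 2 (beyond the scatter). Compound 4 is therefore estimated at 1.1 in this assay, with a range from 0.7 to 1.5.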

Compound 4, distribution coefficient: 1.4
For compound 4 the middle estimate is 0.30 log units below the measured one; the range from low to high includes it.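

In this assay the same kind of change gives a number 0.10 log units lower from compound 3 to compound 4 (within the scatter) and so stays within the usual scatter, whereas on the core of compound 1 it gave a number 0.50 log units lower from compound 1 to compound 2 (beyond the scatter) and lay beyond it. The size seen on the core of compound 1 therefore did not carry over to this pair, but this does not show that the core is what matters, since the place also differs: here the change sits on a saturated chain carbon bound to an aromatic carbon and a nitrogen on an aromatic ring, and each case rests on a single pair. Nothing measured here bears on why the two steps part.

The compounds shown leave open how hydrogen in place of the methyl of compound 2, on the carbon in that same place, would read, which would hold the place constant across the two cores. They also leave open how a propyl chain or a primary amine would read on that carbon in compound 4.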